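Dropping one chloro from the arylidene ring of compound 2

The source may hold more compounds than are shown below. What is called first, only, known or untested is meant among the compounds shown, and "the series" means these compounds.

Compound 1 `COc1ccc(/C=C2\C(=O)N(c3c(Cl)cccc3Cl)c3ccccc32)cc1OC` and compound 2 `O=C1/C(=C\c2c(Cl)cccc2Cl)c2ccccc2N1c1c(Cl)cccc1Cl` share a core and differ in the arylidene ring. In a functional assay on MCF7 cells (Homo sapiens) for cytotoxicity, read by MTT assay, with a stated time of 72 h (a higher number here means that more compound is needed for the effect, a lower number that less compound is needed), compound 1 gives 10 ug/mL. Compound 2 reaches only a limit of this assay, > 100 ug/mL, which is the limit of > 100 ug/mL in this assay, at which 1 of the 2 values shown sits. Compound 2 therefore stands at the weak end of the two numbers shown, with no number of its own. Compound 3 `O=C1/C(=C\c2ccccc2Cl)c2ccccc2N1c1c(Cl)cccc1Cl` is not yet measured; it differs from compound 2 by hydrogen in place of chloro on an aromatic carbon. Within the data shown here, with no measured pair of this kind, the step is expected to be small, in the direction of less compound needed, and possibly within scatter. Compound 3 is expected to give about 80 ug/mL, between 25 ug/mL and 250 ug/mL, a step of an at least 1.2-fold lower number from compound 2 to compound 3 (0.09 log units; that floor lies within the scatter) in this assay.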

Compound 3, concentration for half-maximal effect: 9 ug/mL
Compound 3: the middle estimate sits 8.9-fold (0.95 log units) above what was measured; measured number outside the range, below it.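

In this assay, the change from 2,6-dichlorophenyl to 2-chlorophenyl gives an at least 11-fold lower number from compound 2 to compound 3 (1.04 log units; beyond the scatter), so a single chloro on the arylidene ring, with nothing else altered, accounts for a step beyond the scatter. Compound 1 and compound 2 differ in the arylidene ring as a whole, so that pair could not single out one position. The full size of the step stays unknown, because compound 2 has a limit rather than a number of its own: the limit of > 100 ug/mL in this assay, at which 1 of the 3 values shown sits.

The compounds shown leave open whether the remaining chloro of compound 3 matters as well, as a plain phenyl ring is not among them. They also leave open how a fluoro or an amine would compare with hydrogen at the position changed here.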